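The source may hold more compounds than are shown below. What is called first, only, known or untested is meant among the compounds shown, and "the series" means these compounds.

Working notes on the series. Compound 1 `CC(C)C(=O)OC1CCC(CN2CCN(c3cc(=O)c4cc(C(F)(F)F)cc([N+](=O)[O-])c4s3)CC2)CC1` and compound 2 `CCCC(=O)OC1CCC(CN2CCN(c3cc(=O)c4cc(C(F)(F)F)cc([N+](=O)[O-])c4s3)CC2)CC1` carry two alkyl esters on the same core, compound 3 `O=C(NC1CCC(CN2CCN(c3cc(=O)c4cc(C(F)(F)F)cc([N+](=O)[O-])c4s3)CC2)CC1)c1ccccc1` the corresponding benzamide, and compound 4 `O=C(OC1CCC(CN2CCN(c3cc(=O)c4cc(C(F)(F)F)cc([N+](=O)[O-])c4s3)CC2)CC1)c1ccc(C(F)(F)F)cc1` an aromatic ester that has not yet been measured. In an ADME assay on Vero cells (Chlorocebus sabaeus) for cytotoxicity, read by MTT assay, with a stated time of 48 h (on this read-out higher numbers stand for weaker inhibition and lower numbers for stronger inhibition), compound 1 gives > 64 ug/mL, which is a limit of the assay and not a number. Compound 2 gives > 64 ug/mL in this assay, also a limit. Compound 3 gives 44.3 ug/mL in this assay, a measured number. Compound 2 thus sits at the top of the numbers shown, at the limit of > 64 ug/mL in this assay, at which 2 of the 3 values shown sit. The step that the two limits leave unreadable from compound 1 to compound 2 cannot be read between two limits. The steps of an at least 1.4-fold lower number from compound 1 to compound 3 (0.15 log units; that floor lies within the scatter) and an at least 1.4-fold lower number from compound 2 to compound 3 (0.15 log units; that floor lies within the scatter) are the only readable ones, and both end at a floor that stays within the scatter.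

The change to compound 4 is 4-(trifluoromethyl)phenyl in place of propyl on a carbonyl carbon. The nearest measured step is an at least 1.4-fold lower number from compound 2 to compound 3 (0.15 log units; that floor lies within the scatter), where an aromatic ring also enters in place of the alkyl chain; it gave no movement beyond the scatter. For the measured compounds named here, no larger step is therefore expected here: the step from compound 2 to compound 4 is estimated as an at least 1.1-fold lower number from compound 2 to compound 4 (0.06 log units; that floor lies within the scatter). Compound 4 is expected to give 55 ug/mL in this assay, between 30 ug/mL and 90 ug/mL, with a fair chance that only a limit is reported.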

Compound 4, half-maximal inhibitory concentration: > 64 ug/mL
Compound 4 ended at the assay's limit (the forecaster's own chance of this, stated with the estimate: 45%); at least 1.1-fold (0.06 log units) between middle value and limit.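

In this assay compound 4 gives > 64 ug/mL, a limit of the assay and not a number. Compound 1 and compound 2 also stand at limits, and their steps to compound 4 cannot be read. The compounds shown leave open whether the isopropyl, propyl and 4-(trifluoromethyl)phenyl esters differ at all in this assay, as all three stop at: the limit of > 64 ug/mL in this assay, at which 3 of the 4 values shown sit.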